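The compounds below may be only part of what the source reports. "The series", "measured", "known", "first", "only" and "open" are said of these compounds alone.

Of the compounds shown here, three built on one shared core have been measured in an ADME assay on HeLa cells (Homo sapiens) for cytotoxicity, read by sulforhodamine B assay, with a stated time of 48 h, tested at 10 uM; on this read-out lower numbers stand for less inhibition and higher numbers for more inhibition at the one concentration tested (going by the name of the read-out). Compound 1 `COc1nc2ccc(Br)cc2cc1C(c1ccccc1)n1cc(-c2ccc(Br)cc2)nn1` gives 6.92%. Compound 2 `CCCCCCc1cn(C(c2ccccc2)c2cc3cc(Br)ccc3nc2OC)nn1` gives -0.97%. Compound 3 `COc1nc2ccc(Br)cc2cc1C(c1ccccc1)n1cc(-c2ccc(OC(F)(F)F)cc2)nn1` gives -2.24%. Among these three numbers compound 2 stands second highest: its nearest neighbour is compound 3, with a number 1.3 percentage points lower from compound 2 to compound 3 (within the scatter), and its furthest is compound 1, with a number 7.9 percentage points lower from compound 1 to compound 2 (within the scatter).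

Compound 4 `COc1nc2ccc(Br)cc2cc1C(c1ccccc1)n1cc(CCO)nn1` differs from compound 2 at one place: hydroxy in place of butyl on a saturated chain carbon, two bonds along the chain from an aromatic carbon. The measured steps bear on this only loosely. Replacing the hexyl by a 4-bromophenyl, a number 7.9 percentage points lower from compound 1 to compound 2 (within the scatter), or by a 4-(trifluoromethoxy)phenyl, a number 1.3 percentage points lower from compound 2 to compound 3 (within the scatter), stayed within the scatter, as did a number 9.2 percentage points lower from compound 1 to compound 3 (within the scatter). For the measured compounds named here, no measured step brings in a hydroxy group, and no measured step shortens the chain, so the change to compound 4 is not directly covered. All three numbers seen so far sit close to no inhibition at the single concentration tested, with no group at this position moving the read-out beyond the scatter. The expectation for compound 4 in this assay is accordingly a step of about a number 1 percentage points higher from compound 2 to compound 4 (within the scatter), meaning nothing beyond the scatter. Compound 4 is estimated at 0%, with a range from -9% to 10%.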

Compound 4, a percentage reported as inhibition, at one concentration (the size of the read-out at that concentration, not a potency): 0.85%
Beside the measured number, compound 4's estimate is 0.9 percentage points below it; the measured number falls inside the stated range.
By their numbers in this assay, from the lowest: compounds 3, 2, 4 and 1 (each within the scatter of the next).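

In this assay, a chain ending in a hydroxy group, a hydrogen-bond donor and acceptor that the butyl it replaces lacks, now stands at this position, and cutting hexyl down to 2-hydroxyethyl gives a number 1.8 percentage points higher from compound 2 to compound 4 (within the scatter). Set against the two substituted phenyl groups, the same 2-hydroxyethyl gives a number 3.1 percentage points higher from compound 3 to compound 4 (within the scatter) and a number 6.1 percentage points lower from compound 1 to compound 4 (within the scatter), so this position has now carried a long alkyl chain, a short hydroxylated chain and two aromatic groups, and all four compounds read alike. No outside measurement is available to explain this sameness.

The compounds shown leave open whether any group here can move the read-out beyond the scatter at all, for example an amine such as 2-aminoethyl or a carboxylic acid in place of the hydroxy group. Because each number comes from one concentration, they also leave open how these compounds would compare at higher concentrations, where differences hidden in this narrow band might appear.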